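Title: A phenylethyl group replaces the oxanylmethyl on the ring nitrogen

This account rests on a few compounds, and the source may have more. Where it says the series, first, only, none or still open, it means among the compounds named here.

Measured compounds:
compound 1 `CNC(=O)c1cc(C(=O)NC2CC2)cn(CC2CCCOC2)c1=O`, 2
compound 2 `CNC(=O)c1cc(C(=O)NC2CC2)cn(Cc2ccc3nc[nH]c3c2)c1=O`, 1.2
compound 3 `CNC(=O)c1cc(C(=O)NC2CC2)cn(CC2CCOCC2)c1=O`, 1.5

In a physicochemical assay for lipophilicity, at pH 7.4 (a higher number here means a more lipophilic compound, a lower number a more polar compound), compound 3 gives 1.5, the second highest of the three numbers; compound 1 lies higher, with a number 0.50 log units lower from compound 1 to compound 3 (beyond the scatter), and compound 2 lies within the scatter, with a number 0.30 log units higher from compound 2 to compound 3 (within the scatter). Compound 4 `CNC(=O)c1cc(C(=O)NC2CC2)cn([C@H](C)c2ccccc2)c1=O` is not yet measured. Its change from compound 3 is 1-phenylethyl in place of (oxan-4-yl)methyl on an aromatic nitrogen. Going by the values given here, no measured step swaps an oxanyl ring for a carbon-only aromatic ring; the steps of a number 0.50 log units lower from compound 1 to compound 3 (beyond the scatter) and a number 0.80 log units lower from compound 1 to compound 2 (beyond the scatter) only show that the group on this nitrogen shifts the read-out by modest amounts, and the step of a number 0.30 log units higher from compound 2 to compound 3 (within the scatter) shows a bicyclic aromatic group with a donor and acceptors sitting close to compound 3. The entering 1-phenylethyl carries no donor or acceptor, so a step upward beyond the scatter in this assay is expected. Compound 4 is therefore estimated at 2.7, within 2.1 to 3.3. That estimate means a number 1.20 log units higher from compound 3 to compound 4 (beyond the scatter) is expected.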

Compound 4, distribution coefficient: 3.4
Beside the measured number, compound 4's estimate is 0.70 log units below it, outside the stated range (above it).
By their numbers in this assay, from the lowest: compounds 2 and 3 (each within the scatter of the next); then compound 1; then compound 4.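

In this assay, 1-phenylethyl on the aromatic nitrogen gives a number 1.90 log units higher from compound 3 to compound 4 (beyond the scatter) in place of (oxan-4-yl)methyl, and a number 1.40 log units higher from compound 1 to compound 4 (beyond the scatter) in place of (oxan-3-yl)methyl. Going by these compounds alone, both steps are large, whereas the earlier steps at this position were modest or within the scatter, so the group on this nitrogen can move the read-out much further than those compounds showed. The change replaces a six-membered non-aromatic ring with 1 hetero atom by a six-membered aromatic ring of carbon only, and nothing here explains the size of the step. The compounds shown leave open how much of the step belongs to the aromatic ring and how much to the branching methyl, which a plain benzyl group would separate. They also leave open how far an amine or a carboxylic acid on the phenyl ring would bring the number back.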